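The source may report more compounds than this note shows. Statements on the series, on what has been measured and on what is new or still open speak of the compounds shown alone.

Working notes on the series, read in a functional assay on V79 cells (Cricetulus griseus) for cytotoxicity, read by colony formation; a higher number here means a weaker inhibitor, a lower number a stronger inhibitor. Compound 1 (`COc1c(N2CCC(N)C2)c(F)cc2c(=O)c(C(=O)O)cn(C3CC3)c12`) gives 45 ug/mL; 44 ug/mL; 45 ug/mL (3 entries) across its repeat entries. Compound 2 (`COc1c(N2CCCC(N)C2)c(F)cc2c(=O)c(C(=O)O)cn(C3CC3)c12`) gives 69 ug/mL, the only number shown for it, and one further entry for compound 2 carries no single number. The values of these two compounds lie within the usual scatter of each other.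

Compound 3 (`COc1c(N2CCC(C)(N)C2)c(F)cc2c(=O)c(C(=O)O)cn(C3CC3)c12`) follows from compound 2 by 3-amino-3-methylpyrrolidin-1-yl in place of 3-aminopiperidin-1-yl on an aromatic carbon. The 3-amino-3-methylpyrrolidin-1-yl group replaces 3-aminopiperidin-1-yl on an aromatic carbon, ortho to a fluoro group and ortho to a methoxy group.

Going by the values given here, no measured step isolates this change. With compound 1 at 45 ug/mL; 44 ug/mL; 45 ug/mL (3 entries) and compound 2 at 69 ug/mL, no step beyond the scatter is expected in this assay. The expected change is a 1.3-fold lower number from compound 2 to compound 3 (0.10 log units; within the scatter). Compound 3 is estimated at 55 ug/mL, with an expected range of 27 ug/mL to 110 ug/mL.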

Compound 3, half-maximal inhibitory concentration: 38 ug/mL
Compound 3: the middle estimate sits 1.4-fold (0.16 log units) above what was measured; measured number inside the range.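

In this assay, replacing 3-aminopiperidin-1-yl with 3-amino-3-methylpyrrolidin-1-yl on the aromatic carbon ortho to a fluoro group and ortho to a methoxy group gives a 1.8-fold lower number from compound 2 to compound 3 (0.26 log units; within the scatter). The two groups hold the same atoms, joined differently, so this rearrangement, from a six-membered to a five-membered non-aromatic ring carrying the methyl group, does not move the read-out beyond the scatter at this position. The comparison rests on a single number for compound 2, while repeat entries of compound 1 agree closely: the several entries of compound 1 in this assay, 45 ug/mL; 44 ug/mL; 45 ug/mL (3 entries)

The compounds shown leave open whether a group at this position can move the read-out beyond the scatter. A morpholin-4-yl group, without the primary amine, or a piperazin-1-yl group would test this on the shared core.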